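Methoxy Added to a Pyrimidine: Effect on Cell Tolerance

The compounds below may be only part of what the source reports. "The series", "measured", "known", "first", "only" and "open" are said of these compounds alone.

Three compounds have been measured in an ADME assay on MT2 cells (Homo sapiens) for cytotoxicity; a lower number here means that less compound is tolerated, a higher number that more compound is tolerated:
Compound 1 `CC(C)=CCOc1cc(Nc2nccc(N)n2)ccc1Cl` gives 500 nM.
Compound 2 `COc1cc(N)nc(Nc2ccc(Cl)c(OCC=C(C)C)c2)n1` gives 19000 nM.
Compound 3 `C/C=C/COc1cc(Nc2ncccn2)ccc1Cl` gives 31000 nM.

Compound 1 and compound 2 differ only by methoxy in place of hydrogen on an aromatic carbon, and that change made the step of a 38-fold higher number from compound 1 to compound 2 (1.58 log units; beyond the scatter). The difference between the cores of compound 1 and compound 3 is not broken down here; their values show that compound 3 is tolerated at a far higher concentration, while compound 3 and compound 2 lie within the usual scatter of each other.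

Compound 4 `C/C=C/COc1cc(Nc2nccc(OC)n2)ccc1Cl` carries the same kind of change relative to compound 3, (methoxy in place of hydrogen on an aromatic carbon), though the surroundings differ: in compound 2 the place is also meta to an amino group (1 heavy atom). Because of a 38-fold higher number from compound 1 to compound 2 (1.58 log units; beyond the scatter) a rise is expected here as well. The step is expected to be a 2.3-fold higher number from compound 3 to compound 4 (0.35 log units; beyond the scatter) in this assay, kept modest since compound 3 already stands at 31000 nM. Compound 4 is thus estimated at 70000 nM, expected between 25000 nM and 200000 nM.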

Compound 4, half-maximal cytotoxic concentration: 17000 nM
Compound 4: the middle estimate sits 4.1-fold (0.61 log units) above what was measured; measured number outside the range, below it.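

Methoxy in place of hydrogen on an aromatic carbon gave a 1.8-fold lower number from compound 3 to compound 4 (0.26 log units; within the scatter) in this assay, so on this core the change has no effect that can be told from the scatter. The large step seen on the core of compound 1 therefore does not carry over to the core of compound 3: the same change on two cores in this assay, a 38-fold higher number (1.58 log units; beyond the scatter) from compound 1 to compound 2 and a 1.8-fold lower number (0.26 log units; within the scatter) from compound 3 to compound 4, 69-fold (1.84 log units) apart, beyond the scatter of two such steps. This does not show which feature of the cores is responsible, as compound 1 and compound 2 carry an amino group that compound 3 and compound 4 lack, and the two pairs also differ in their ether chain.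

As far as these compounds go, whether the amino group or the chain matters more remains open. So does how a different group in the same place, such as ethoxy or chlorine, would behave on either core.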